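Cholesterol 24-hydroxylase series: amide terminus variation

The source may hold more compounds than are shown below. What is called first, only, known or untested is meant among the compounds shown, and "the series" means these compounds.

Measured compounds:
compound 1 `O=C(NC1CC1)N1CCC(c2cnccc2-c2ccccc2)CC1` 950 nM
compound 2 `O=C(NC1CC1)N1CCN(c2cnccc2-c2ccccc2)CC1` 52 nM
compound 3 `O=C(NC1CC1)C1CCN(c2cncnc2-c2ccccc2)CC1` 44 nM

In an assay on HEK293F cells for inhibition of cholesterol 24-hydroxylase (Homo sapiens), read by trypan blue exclusion, with stated times of 15 min and 5 h (on this read-out lower numbers stand for stronger inhibition and higher numbers for weaker inhibition), compound 3 gives 44 nM, the lowest of the three numbers; compound 2 lies within the scatter of it, while compound 1 sits well beyond the scatter at the weaker end. Going by the values given here, no measured pair differs in a single place, so no step stands on its own.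

Compound 4 `CN(C)C(=O)C1CCN(c2cncnc2-c2ccccc2)CC1` is not yet measured. It differs from compound 3 by dimethylamino in place of cyclopropylamino on a carbonyl carbon. Among the compounds with values here, no measured pair shows a change of this kind, so the expectation rests on compound 3 alone. A modest shift toward a higher number, just beyond the scatter, is expected, a 2.7-fold higher number from compound 3 to compound 4 (0.44 log units; beyond the scatter). Compound 4 is estimated at 120 nM, within 40 nM to 400 nM.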

Compound 4, half-maximal inhibitory concentration in the cholesterol 24-hydroxylase assay: 16 nM
Compound 4: the middle estimate sits 7.5-fold (0.88 log units) above what was measured; the whole stated range lies above it.
By their numbers in the cholesterol 24-hydroxylase assay, from the lowest: compound 4; then compounds 3 and 2 (each within the scatter of the next); then compound 1.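

In the cholesterol 24-hydroxylase assay, compound 3 gives 44 nM and compound 4 gives 16 nM; dimethylamino in place of cyclopropylamino on a carbonyl carbon gives a 2.8-fold lower number from compound 3 to compound 4 (0.44 log units; beyond the scatter), so inhibition at this position survives losing both the three-membered ring and the amide hydrogen. In a physicochemical assay for lipophilicity, at pH 7.4 (a lower number here means a more polar compound, a higher number a more lipophilic compound), compound 3 gives 1.8 and compound 4 gives 1.7; the same change gives a number 0.10 log units lower from compound 3 to compound 4 (within the scatter), so that read-out does not separate the two compounds. Nothing shown gives a cause for the step in inhibition.

Going by these compounds, the ring and the amide hydrogen leave together in this one step, so their separate contributions remain open. Methylamino or azetidin-1-yl on the same carbonyl carbon would pull the two apart.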